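The compounds below may be only part of what the source reports. "The series", "measured", "known", "first", "only" and "open" are said of these compounds alone.

Compound 1 `COc1ccc(-c2c(C)nc3c(N4CC[C@@H](NC(C)=O)C4)cc(C)nn23)cc1OC`, compound 2 `COc1ccc(-c2c(C)nc3c(N4CC[C@@H](NS(N)(=O)=O)C4)cc(C)nn23)cc1OC` and compound 3 `COc1ccc(-c2c(C)nc3c(N4CC[C@@H](O)C4)cc(C)nn23)cc1OC` share a core and were tested in an ADME assay on microsomes from liver (Homo sapiens) for metabolic stability, read by LC-MS, with NADPH named in the record, with a stated time of 60 min, tested at 1 uM, in the absence of a further agent; on this read-out lower numbers stand for a less stable compound and higher numbers for a more stable compound. Compound 1 gives > 95%, which is a limit of the assay. Compound 2 gives > 95%, also a limit. Compound 3 gives > 95%, again a limit and not a number. The measured picture is therefore (the limit of > 95% in this assay, at which 3 of the 3 values shown sit).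

Compound 4 `COc1ccc(-c2c(C)nc3c(N4CC[C@@H](SC(C)=O)C4)cc(C)nn23)cc1OC` has acetylsulfanyl in place of hydroxy on a saturated ring carbon. The changes closest to this are a step that the two limits leave unreadable from compound 1 to compound 3 and a step that the two limits leave unreadable from compound 2 to compound 3, and a step that the two limits leave unreadable from compound 1 to compound 2 also bears on it. Within the data shown here, none of these gives a size to carry over, and no measured compound carries acetylsulfanyl.

In this assay, a fall of uncertain size is expected, estimated as a number at least 20 percentage points lower from compound 3 to compound 4 (beyond the scatter). The estimate for compound 4 is 75%, with an expected range from 35% to 100%.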

Compound 4, percent of the compound remaining: > 95%
Compound 4: only a limit was reported; the forecaster's own chance of this, stated with the estimate: 30%; middle value at least 20 percentage points away from the limit.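

Compound 4 sits at a limit, as do compound 1, compound 2 and compound 3, so no step among them can be read: the limit of > 95% in this assay, at which 4 of the 4 values shown sit.

From the compounds shown here alone, whether these four compounds differ in stability at all stays open, with no number for any of them.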